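A Sugar Replaces an Acetyl on an Aromatic Nitrogen

The compounds below may be only part of what the source reports. "The series", "measured", "known", "first", "only" and "open" are said of these compounds alone.

Compound 1, `C[C@H](/C=C/C=C/C=C/[C@H](O)CC(=O)O)[C@@H](O)[C@H](C)C[C@@H](C)[C@H](O)CC(=O)c1ccc(N)cc1`, in a functional assay on K562 cells (Homo sapiens) for cytotoxicity, read by sulforhodamine B assay, with a stated time of 72 h (on this read-out higher numbers stand for weaker inhibition and lower numbers for stronger inhibition), reaches only the limit > 10000 nM.
Compound 2, `CNc1ccc(C(=O)C[C@@H](O)[C@H](C)C[C@@H](C)[C@H](O)[C@H](C)/C=C/C=C/C=C/[C@H](O)CC(=O)O)cc1`, in this assay reaches only the limit > 10000 nM.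
Compound 3, `CC(=O)Nc1ccc(C(=O)C[C@@H](O)[C@H](C)C[C@@H](C)[C@H](O)[C@H](C)/C=C/C=C/C=C/[C@H](O)CC(=O)O)cc1`, in this assay reaches only the limit > 10000 nM.

Compound 3 stands at a limit of this assay rather than at a number, and the two other compounds stand at the same limit, so no ordering among the three can be read; this is recorded as the limit of > 10000 nM in this assay, at which 3 of the 3 values shown sit. The steps a step that the two limits leave unreadable from compound 1 to compound 2, a step that the two limits leave unreadable from compound 1 to compound 3 and a step that the two limits leave unreadable from compound 2 to compound 3 are all of unreadable size for the same reason: every value involved is a limit.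

Compound 4, `C[C@H](/C=C/C=C/C=C/[C@H](O)CC(=O)O)[C@@H](O)[C@H](C)C[C@@H](C)[C@H](O)CC(=O)c1ccc(N[C@@H]2O[C@H](CO)[C@@H](O)[C@H](O)[C@H]2O)cc1`, differs from compound 3 in one place: 3,4,5-trihydroxy-6-(hydroxymethyl)oxan-2-yl in place of acetyl on a nitrogen on an aromatic ring. Among the compounds with values here, none of the measured steps bears directly on this change, since none of them involved a 3,4,5-trihydroxy-6-(hydroxymethyl)oxan-2-yl group on the aromatic nitrogen, and none gave a readable size. With hydrogen, methyl and acetyl on that nitrogen all leaving the compounds at the limit, the expectation is that compound 4 remains there as well, so the expected step that the limit leaves unreadable from compound 3 to compound 4 is none beyond the scatter. For compound 4 in this assay the estimate is 20000 nM, with an expected range from 7000 nM to 60000 nM.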

Compound 4, half-maximal inhibitory concentration: > 10000 nM
Compound 4 was reported as a limit; the forecaster's own chance of this, stated with the estimate: 80%; the middle value lies beyond the limit too.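

In this assay compound 4 gives > 10000 nM, which is a limit and not a number. No new step can be read between compound 4 and compound 1, compound 2 or compound 3, because all four sit at the same limit: the limit of > 10000 nM in this assay, at which 4 of the 4 values shown sit. The compounds shown leave open whether any of these groups on the aromatic nitrogen changes cytotoxicity at all.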